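Adding a Chloro Group to Compound 3

The compounds below may be only part of what the source reports. "The series", "measured", "known", "first", "only" and "open" are said of these compounds alone.

Measured so far in a functional assay on HCT-116 cells (Homo sapiens) for antiproliferative activity, read by MTT assay, with a stated time of 48 h; a higher number here means a weaker inhibitor, a lower number a stronger inhibitor:
- compound 1 `COc1ccc(N(C)c2ccnc(Cl)n2)cc1[N+](=O)[O-]` gives 4700 nM
- compound 2 `COc1ccc(N(C)c2ccnc(Cl)n2)cc1OCCBr` gives 5670 nM
- compound 3 `COc1ccc(N(C)c2cc(C)nc(C)n2)cc1` gives 1320 nM

A lower number means a stronger inhibitor, so compound 3 is the strongest of the three, and its value lies beyond the scatter from both others. Compound 3 also differs from compound 1 and compound 2 in more than one place, so those gaps cannot be pinned on any single group.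

The next compound is compound 4 `COc1ccc(N(C)c2cc(C)nc(C)n2)cc1Cl`, which has one change from compound 3: chloro in place of hydrogen on an aromatic carbon. The chloro replaces hydrogen on an aromatic carbon, ortho to a methoxy group.

Going by the values given here, only one measured step offers a guide, and it is indirect: a 1.2-fold higher number from compound 1 to compound 2 (0.08 log units; within the scatter). There, 2-bromoethoxy stands in place of nitro on an aromatic carbon, and the change stays within the scatter. Among the compounds with values here, no measured step shows a group replacing hydrogen, so this guide is weak. A small change is therefore expected, with no clear shift beyond the scatter, though the uncertainty runs wide.

The expected step is a 1.4-fold higher number from compound 3 to compound 4 (0.13 log units; within the scatter) and leans slightly towards a weaker number. For compound 4 the estimated value is 1800 nM, within an expected range of 600 nM to 5500 nM when measured.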

Compound 4, half-maximal inhibitory concentration: 1190 nM
Compound 4: middle estimate off by 1.5-fold (0.18 log units), on the high side, and the stated range covers the measured number.
By their numbers in this assay, from the lowest: compounds 4 and 3 (each within the scatter of the next); then compounds 1 and 2 (each within the scatter of the next).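

In this assay the swap of hydrogen for chloro is a 1.1-fold lower number from compound 3 to compound 4 (0.05 log units; within the scatter) and so lies within the usual scatter of repeated measurements; the readings for the two compounds cannot be told apart. Among the compounds shown, this is the only step in which a group replaces a hydrogen, and it shows that a single chlorine atom can sit on this aromatic carbon, ortho to a methoxy group, on the shared core of compound 3 with no detectable effect on the antiproliferative reading. Going by these compounds alone, no supporting measurement is available to explain this result, so the data record only that the two readings match and offer no reason for it.

Still open, going by these compounds, is how this position responds to a group other than chloro on this same core, such as an amine, a carboxylic acid or a longer chain, any of which could give a step beyond the scatter. Also open, on these data alone, is whether chloro on a different carbon of the same ring would give an equally small step.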